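Urea Aryl Swap and Dopamine Transporter Inhibition

This account rests on a few compounds, and the source may have more. Where it says the series, first, only, none or still open, it means among the compounds named here.

Measured compounds:
compound 1 `O=C(NCCCCC(c1ccc(F)cc1)c1ccc(F)cc1)Nc1ccc(I)cc1` gives 24% in an ADME assay on isolated protein for inhibition of sodium-dependent dopamine transporter (Homo sapiens), tested at 10 uM; on this read-out higher numbers stand for more inhibition at the one concentration tested (going by the name of the read-out) and lower numbers for less inhibition
compound 2 `CC(=O)Nc1cc(NC(=O)NCCCCC(c2ccc(F)cc2)c2ccc(F)cc2)ccc1Cl` gives 76% in this assay

Compound 2 stands highest of the two numbers in this assay; its nearest neighbour is compound 1, and the step of a number 52 percentage points higher from compound 1 to compound 2 (beyond the scatter) lies beyond the scatter. Within the data shown here, that step exchanges one aryl group on an amide-type nitrogen for another and is the only measured step bearing on compound 3 `O=C(NCCCCC(c1ccc(F)cc1)c1ccc(F)cc1)Nc1ccc(Cl)cc1C(F)(F)F`. Compound 3 differs from compound 2 by 4-chloro-2-(trifluoromethyl)phenyl in place of 3-acetamido-4-chlorophenyl on an amide-type nitrogen. Compound 3 again carries a halogen on its aryl group and lacks the acetamido group, so it resembles compound 1 in that respect, while compound 1 gave the low value 24%. Among the measured compounds shown here, because the one measured step of a number 52 percentage points higher from compound 1 to compound 2 (beyond the scatter) was large, a step of moderate size downward is expected, a number 31 percentage points lower from compound 2 to compound 3 (beyond the scatter). Compound 3 is therefore estimated at 45% in this assay, with a range from 15% to 78%.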

Compound 3, a percentage reported as inhibition, at one concentration (the size of the read-out at that concentration, not a potency): 20%
Compound 3: the middle estimate sits 25 percentage points above what was measured; the range from low to high includes it.
By their numbers in this assay, from the lowest: compounds 3 and 1 (each within the scatter of the next); then compound 2.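

In this assay, the aryl group on the amide-type nitrogen matters in a second case: 4-chloro-2-(trifluoromethyl)phenyl in place of 3-acetamido-4-chlorophenyl gives a number 56 percentage points lower from compound 2 to compound 3 (beyond the scatter) even though both groups carry a chlorine, so chlorine on this aryl group is not enough for the high number. Against 4-iodophenyl, the same group gives a number 4 percentage points lower from compound 1 to compound 3 (within the scatter), so these two aryl groups cannot be told apart here and only the group in compound 2 stands clear of them. Nothing measured here explains why the number changes with the aryl group.

From the compounds shown here alone, it remains open whether the acetamido group would hold the high number without the chlorine on the same ring. Also open, going by these compounds, is how an amine or a carboxylic acid in its place would read.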